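The compounds below may be only part of what the source reports. "The series", "measured", "known", "first", "only" and "open" are said of these compounds alone.

Compound 1, `CCOC(=O)CC1C(C(=O)OCC)=C(N)Oc2ccc(-c3ccc(N)cc3)cc21`, gives 22300 nM in a functional assay on HL-60 cells (Homo sapiens) for cytotoxicity, read by CellTiter-Blue, with a stated time of 48 h; a higher number here means a weaker inhibitor, a lower number a stronger inhibitor.
Compound 2, `C#CCOC(=O)CC1C(C(=O)OCC)=C(N)Oc2ccc(-c3ccc(N)cc3)cc21`, gives 10500 nM in this assay.
Compound 3, `C#CCOC(=O)CC1C(C(=O)OCC)=C(N)Oc2ccc(-c3ccc(NCC)cc3)cc21`, gives 33000 nM in this assay.

Of the compounds shown here, three sharing one core have been measured so far. Compound 2 differs from compound 1 by a single change, (ethynyl in place of methyl on a saturated chain carbon bound to an oxygen next to a carbonyl group), and this change brings a 2.1-fold lower number from compound 1 to compound 2 (0.33 log units; beyond the scatter), a modest gain in potency that lies beyond the usual scatter. Compound 3 differs from compound 2 at a different place, with ethyl in place of hydrogen on a nitrogen on an aromatic ring, and here the number moves the other way: a 3.1-fold higher number from compound 2 to compound 3 (0.50 log units; beyond the scatter). Compound 3 and compound 1 differ in more than one place, so the difference between the two cores is not broken down here; their two values lie within the scatter of each other.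

Compound 4, `C#CCOC(=O)CC1C(C(=O)OCC#C)=C(N)Oc2ccc(-c3ccc(NCC)cc3)cc21`, has not yet been measured. It differs from compound 3 by ethynyl in place of methyl on a saturated chain carbon bound to an oxygen next to a carbonyl group. Going by the values given here, this is the same change as the one from compound 1 to compound 2, made at the same place, so the earlier step is the only guide. The change is expected to bring a 2.1-fold lower number from compound 3 to compound 4 (0.33 log units; beyond the scatter) because the only prior case of this change is a 2.1-fold lower number from compound 1 to compound 2 (0.33 log units; beyond the scatter) and the second change on the aromatic nitrogen is carried along unchanged. On that basis compound 4 is estimated at 15500 nM in this assay, with a likely range from 7000 nM to 34000 nM.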

Compound 4, half-maximal inhibitory concentration: 7270 nM
For compound 4 the middle estimate is 2.1-fold (0.33 log units) above the measured one, within the range that was stated.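

In this assay, swapping ethoxycarbonyl for propargyloxycarbonyl again lowers the number, with a 4.5-fold lower number from compound 3 to compound 4 (0.66 log units; beyond the scatter), a modest gain in potency. Set side by side, the two steps point the same way and cannot be told apart in size: the same change on two cores in this assay, a 2.1-fold lower number (0.33 log units; beyond the scatter) from compound 1 to compound 2 and a 4.5-fold lower number (0.66 log units; beyond the scatter) from compound 3 to compound 4, 2.1-fold (0.33 log units) apart, within the scatter of two such steps. Going by these compounds alone, this suggests that, within these compounds, the swap carries over from a core with a free amine on the aromatic ring to one with an ethyl group on that nitrogen, but it rests on only two pairs, the two steps do not act on the same ester (compound 4 takes the swap on the ethoxycarbonyl group that compound 3 still carries), and neither pair shows why the number falls or whether the swap would hold on other cores.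

The compounds shown leave open how the number would read with propargyloxycarbonyl on the second ester alone, with the first kept as ethoxycarbonyl, which would separate the two esters more cleanly. They also leave open whether a longer chain on the ester, such as butynyl, or a carboxylic acid in place of either ester would keep the gain, and how a propyl group on the aromatic nitrogen would behave.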